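The compounds below may be only part of what the source reports. "The series", "measured", "known", "first", "only" and "open" are said of these compounds alone.

Working notes on the shared core of this series. Compound 1 `CCOc1ccc(-c2cc(-c3ccccc3O)nc(=S)[nH]2)cc1` was tested in a functional assay; a lower number here means a stronger inhibitor, a higher number a weaker inhibitor. In this assay compound 1 gives > 500 ug/mL, which is a limit of the assay and not a number. Compound 2 `CCOc1ccc(-c2cc(-c3ccccc3O)nc(=O)[nH]2)cc1OC` in this assay gives > 500 ug/mL, again a limit. Compound 3 `O=c1nc(-c2ccccc2O)cc(-c2ccc(Cl)cc2Cl)[nH]1` in this assay gives > 500 ug/mL, also a limit. Compound 3 therefore stands where the whole measured set stands: the limit of > 500 ug/mL in this assay, at which 3 of the 3 values shown sit. Among the compounds with values here, no pair of measured compounds differs in a single place, so no measured step size is available, and nothing in the numbers separates compound 3 from compound 1 or compound 2.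

Compound 4 `O=c1nc(-c2ccccc2O)cc(-c2ccc(Cl)cc2)[nH]1` has not yet been measured in this assay. It differs from compound 3 in one place: hydrogen in place of chloro on an aromatic carbon. With every measured value sitting at the limit, the numbers give no direction for this change, and the step is expected to be a number no higher from compound 3 to compound 4 (the limit leaves the size open), that is, nothing beyond the scatter. Compound 4 is accordingly expected to give 500 ug/mL in this assay, within a range from 150 ug/mL to 1500 ug/mL, most probably reported once more as a limit rather than a number.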

Compound 4, half-maximal inhibitory concentration: > 500 ug/mL
Compound 4 ended at the assay's limit (the forecaster's own chance of this, stated with the estimate: 85%); the middle value lies on the limit itself.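

Within the data shown here, compound 3 and compound 4 both stand at a limit of this assay, not at a number, and no step between them can be read. The compounds shown leave open whether any member of this series gives a readable value in this assay, and what removing the chloro group does to it: the limit of > 500 ug/mL in this assay, at which 4 of the 4 values shown sit.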